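The compounds below may be only part of what the source reports. "The series", "measured", "known", "first", "only" and "open" are said of these compounds alone.

For the measured compounds named here, in a functional assay on cells (leukaemia cell line, Homo sapiens) for inhibition, read by sulforhodamine B assay, with a stated time of 48 h (on this read-out higher numbers stand for weaker inhibition of growth and lower numbers for stronger inhibition of growth), compound 1 `O=S(=O)(Nc1ccc(Cl)c(F)c1)c1ccc(-c2cnc(C3CC3)o2)cc1` gives 63000 nM, and compound 2 `O=S(=O)(Nc1ccc(I)c(Cl)c1)c1ccc(-c2cnc(C3CC3)o2)cc1` gives 19600 nM, the lower of the two numbers so far. Going by the values given here, the only measured step is a 3.2-fold lower number from compound 1 to compound 2 (0.51 log units; beyond the scatter), a modest one, with 3-chloro-4-iodophenyl in place of 4-chloro-3-fluorophenyl on a sulfonamide nitrogen.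

Compound 3 `Cc1cc(F)cc(NS(=O)(=O)c2ccc(-c3cnc(C4CC4)o3)cc2)c1` is still unmeasured. The change to it is 3-fluoro-5-methylphenyl in place of 3-chloro-4-iodophenyl on a sulfonamide nitrogen. Among the compounds with values here, the same place on the sulfonamide nitrogen is altered again, so the one measured step is the only guide, and a single pair gives thin support. The entering 3-fluoro-5-methylphenyl holds fluorine, as the group in compound 1 does, and has neither the chlorine nor the iodine of compound 2. A modest step towards a higher number in this assay is therefore expected, of similar size to the measured one and in the opposite direction, with no gain on compound 2 anticipated. The estimated change is a 2.6-fold higher number from compound 2 to compound 3 (0.41 log units; beyond the scatter). For compound 3 the estimate is 50000 nM, with an expected range of 20000 nM to 120000 nM.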

Compound 3, concentration for total growth inhibition: 7250 nM
Compound 3: the middle estimate sits 6.9-fold (0.84 log units) above what was measured; the whole stated range lies above it.
By their numbers in this assay, from the lowest: compound 3; then compound 2; then compound 1.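

In this assay, the sulfonamide nitrogen position gives a 2.7-fold lower number from compound 2 to compound 3 (0.43 log units; beyond the scatter), and the wider comparison gives an 8.7-fold lower number from compound 1 to compound 3 (0.94 log units; beyond the scatter), so compound 3 now has the lowest number of the three, with both steps beyond the scatter. Neither chlorine nor iodine is needed for a lower number here, as 3-fluoro-5-methylphenyl has neither, and fluorine alone does not set the order, since compound 1, with the highest number, and compound 3, with the lowest, both carry it. The two aryl groups exchanged between compound 2 and compound 3 have the same count of heavy atoms, and no supporting data bear on why the number falls.

The compounds shown do not separate the contribution of the methyl from that of the fluorine in 3-fluoro-5-methylphenyl, as the two enter together in one group. Also open, going by these compounds, is how this position responds to a methoxy group, a primary amine or a carboxylic acid on the phenyl ring, and whether any change on the shared core would move the number further than these aryl exchanges do.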